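From 2-Methoxyphenyl to 4-Methoxyphenyl in Compound 3

The source may report more compounds than this note shows. Statements on the series, on what has been measured and on what is new or still open speak of the compounds shown alone.

In a functional assay on cells (Macrophage, Homo sapiens) for cytotoxicity, read by MTT assay, with a stated time of 24 h (on this read-out lower numbers stand for stronger inhibition and higher numbers for weaker inhibition), compound 1 (`Cc1ccc(N2CCN(CC(O)COc3cc(=O)oc4ccccc34)CC2)c(C)c1`) gives 127000 nM and compound 2 (`COc1ccccc1N1CCN(CC(O)COc2cc(=O)oc3ccccc23)CC1`) gives 256000 nM. Compound 3 (`COc1ccccc1N1CCN(C(=O)COc2cc(=O)oc3ccccc23)CC1`) gives 164000 nM, within the scatter of both, so the three cannot be ranked. Compound 4 (`COc1ccc(N2CCN(C(=O)COc3cc(=O)oc4ccccc34)CC2)cc1`) has 4-methoxyphenyl in place of 2-methoxyphenyl on an amine nitrogen in a ring. The nearest measured evidence is a 2.0-fold higher number from compound 1 to compound 2 (0.30 log units; within the scatter), which exchanges 2,4-dimethylphenyl for 2-methoxyphenyl at that kind of nitrogen and stays within the scatter. For the measured compounds named here, no measured pair tests this exact exchange. The expected change is therefore none beyond the scatter, with an estimated step of a 1.0-fold higher number from compound 3 to compound 4 (0.02 log units; within the scatter). In this assay compound 4 is expected at 170000 nM, with an estimated range from 85000 nM to 340000 nM.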

Compound 4, half-maximal inhibitory concentration: 192000 nM
Estimate against measurement, compound 4: 1.1-fold (0.05 log units) below; the range from low to high includes it.
By their numbers in this assay, from the lowest: compounds 1, 3, 4 and 2 (each within the scatter of the next).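

In this assay, the exchange of 2-methoxyphenyl for 4-methoxyphenyl on an amine nitrogen in a ring gives a 1.2-fold higher number from compound 3 to compound 4 (0.07 log units; within the scatter), and this pair tests that exchange directly. Compound 3 and compound 4 therefore cannot be told apart on this read-out. No evidence on the reason for this result is available. From the compounds shown here alone, whether a carboxylic acid or an amine on the phenyl ring would give a step beyond the scatter remains open. So does whether the same exchange would hold in the series of compound 2.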